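Taking a large group off compound 2

This account rests on a few compounds, and the source may have more. Where it says the series, first, only, none or still open, it means among the compounds named here.

Measured so far in a functional assay on HepG2 cells (Homo sapiens) for cytotoxicity, read by MTT assay, with a stated time of 48 h; on this read-out higher numbers stand for weaker inhibition and lower numbers for stronger inhibition 
compound 1 `Cc1n[nH]c2c1C(c1ccc(N(C)C)cc1)C(C(=O)NN)=C(N)N2` gives 66400 nM 
compound 2 `Cc1n[nH]c2c1C(c1ccc(N(C)C)cc1)C(C(=O)N/N=C1/C(=O)Nc3ccccc31)=C(N)N2` gives 57900 nM 

Among the compounds with values here, compound 2 stands level with compound 1, the only other compound with a number, as the two lie within the scatter of each other. Compound 3 `Cc1n[nH]c2c1C(c1ccc(N(C)C)cc1)C(C(N)=O)=C(N)N2` has no number yet. The change from compound 2 is a hydrogen atom in place of a group of 11 heavy atoms (8 carbon, 2 nitrogen, 1 oxygen; one five-membered non-aromatic ring with 1 hetero atom, one six-membered aromatic ring of carbon only), on an amide-type nitrogen and it sits on an amide-type nitrogen.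

Within the data shown here, only one measured step bears on this. That same group, put in place of one nitrogen atom on this amide-type nitrogen, gives a 1.1-fold lower number from compound 1 to compound 2 (0.06 log units; within the scatter) and nothing larger. Among the measured compounds shown here, the comparison is close but not exact, since compound 3 carries a hydrogen atom at the place where compound 1 carries a nitrogen atom, and no measured compound carries that hydrogen atom alone. Resting on this single step, no change beyond the scatter is expected in this assay here. The expected step is a 1.0-fold higher number from compound 2 to compound 3 (0.02 log units; within the scatter) and so is no more than a small one. For compound 3 the estimated value is 60000 nM with an expected range from 28000 nM to 125000 nM for repeated measurements.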

Compound 3, half-maximal inhibitory concentration: 5280 nM
Compound 3: middle estimate off by 11-fold (1.06 log units), on the high side, and the stated range ends above it.
By their numbers in this assay, from the lowest: compound 3; then compounds 2 and 1 (each within the scatter of the next).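

Replacing the large group with a hydrogen atom on the amide-type nitrogen in this assay gives an 11-fold lower number from compound 2 to compound 3 (1.04 log units; beyond the scatter) and shows that this position can strongly affect the read-out, which the earlier pair did not reveal. Replacing amino with hydrogen at the same place gives a 13-fold lower number from compound 1 to compound 3 (1.10 log units; beyond the scatter) and, since compound 1 and compound 2 lie within the scatter of each other, the amino group and the much larger group give matching results, while only the hydrogen stands apart among these three compounds. No measurement at hand explains this shift.

Among the compounds shown, this nitrogen carries only hydrogen, amino or the one large group, so it remains open whether a small carbon group such as methyl or acetyl would give a number like that of compound 3 or like those of compound 1 and compound 2. Also open, as far as these compounds go, is how a carboxylic acid in place of the amide would read, and whether compound 3 stands apart in the same way on other cell types.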